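The source may hold more compounds than are shown below. What is called first, only, known or untested is meant among the compounds shown, and "the series" means these compounds.

Measured in a functional assay on MDA-MB-231 cells (Homo sapiens) for antiproliferative activity, read by MTT assay, with a stated time of 48 h; on this read-out higher numbers stand for weaker inhibition of growth and lower numbers for stronger inhibition of growth:
compound 1 `COC(=O)N1N=C(c2ccc(OC)cc2)CC1c1cc(OC)c(OC)c(OC)c1`: 1990 nM
compound 2 `CCCOC(=O)N1N=C(c2ccc(OC)cc2)CC1c1cc(OC)c(OC)c(OC)c1`: 20400 nM
compound 3 `COc1ccc(C2=NN(C(=O)OCc3ccccc3)C(c3cc(OC)c(OC)c(OC)c3)C2)cc1`: > 10000 nM, a limit of the assay

Compound 1 holds the lower of the two actual numbers. The entry for compound 3 is a limit.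

Compound 4 `COC(=O)N1N=C(c2cccc(C)c2)CC1c1cc(OC)c(OC)c(OC)c1` keeps the core of compound 1 but carries 3-methylphenyl in place of 4-methoxyphenyl on a carbon with a double bond to nitrogen. Among the compounds with values here, no measured step touches that place. The two steps that bear on it only indirectly, a 10-fold higher number from compound 1 to compound 2 (1.01 log units; beyond the scatter) and an at least 5.0-fold higher number from compound 1 to compound 3 (0.70 log units; beyond the scatter), altered the methoxycarbonyl group instead, the first large and the second at least modest. Since both moved upward from compound 1, the step expected in this assay is modest and upward, a 2.0-fold higher number from compound 1 to compound 4 (0.30 log units; within the scatter). Compound 4 is estimated at 4000 nM, with an expected range of 1000 nM to 15000 nM.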

Compound 4, concentration for 50% growth inhibition: 140 nM
Compound 4: middle estimate off by 29-fold (1.46 log units), on the high side, and the stated range ends above it.
By their numbers in this assay, from the lowest: compound 4; then compound 1; then compound 2.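

In this assay, 3-methylphenyl in place of 4-methoxyphenyl on a carbon with a double bond to nitrogen gives a 14-fold lower number from compound 1 to compound 4 (1.15 log units; beyond the scatter) and is the only downward step shown. This position can therefore lower the number, whereas both readable changes to the methoxycarbonyl group raised it. Nothing given here accounts for the size of this step.

Still open, from the compounds shown here alone, is whether the step follows the methyl group or its place on the phenyl ring. 3-Methoxyphenyl and 4-methylphenyl at this carbon would separate the two.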